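Hydroxy for fluoro on the aniline of compound 1

The compounds below may be only part of what the source reports. "The series", "measured", "known", "first", "only" and "open" are said of these compounds alone.

Compound 1 `Fc1cccc(Nc2nc(-c3ccncc3)cs2)c1`: 40700 nM
Compound 2 `C#Cc1cnccc1-c1csc(Nc2cccc(C)c2)n1`: 1380 nM
Compound 3 `Cc1cccc(Nc2nc(-c3ccncc3-c3ccc(C(C)C)cc3)cs2)c1`: > 40000 nM; 40700 nM (2 entries)

In a functional assay on RCC4 cells (Homo sapiens) for inhibition, read by XTT assay, with a stated time of 4 days (a lower number here means a stronger inhibitor, a higher number a weaker inhibitor), compound 1 gives 40700 nM, the highest of the two plain numbers; compound 2 gives 1380 nM, a gap beyond the scatter. For compound 3 the repeated entries the several entries of compound 3 in this assay, > 40000 nM; 40700 nM (2 entries) include a limit of the assay rather than a single number. Compound 4 `Oc1cccc(Nc2nc(-c3ccncc3)cs2)c1` differs from compound 1 by hydroxy in place of fluoro on an aromatic carbon. Within the data shown here, no measured pair shows this change, so in this assay the step from compound 1 to compound 4 is expected to be small, with a mild lean toward a lower number. Compound 4 is therefore estimated at 25000 nM, between 5000 nM and 60000 nM, which means an expected step of a 1.6-fold lower number from compound 1 to compound 4 (0.21 log units; within the scatter).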

Compound 4, half-maximal inhibitory concentration: 28800 nM
Estimate against measurement, compound 4: 1.2-fold (0.06 log units) below; low and high end bracket the measured number.
By their numbers in this assay, from the lowest: compound 2; then compounds 4 and 1 (each within the scatter of the next).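

Hydroxy in place of fluoro brings in a hydrogen-bond donor and a hydrogen-bond acceptor on an aromatic carbon, meta to a large group. In this assay this swap gives a 1.4-fold lower number from compound 1 to compound 4 (0.15 log units; within the scatter) and so does not separate the two groups at this place. The earlier compounds shown here held no such single-change pair. Going by these compounds, whether an amine, a carboxylic acid or a methoxy group on the same carbon would stay as close to compound 1 remains open. No measurement shown here bears on the reason for this result.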